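Dimethylphenyl ether in place of a trifluoromethylphenyl ether

The source may hold more compounds than are shown below. What is called first, only, known or untested is meant among the compounds shown, and "the series" means these compounds.

For the measured compounds named here, compound 2 `O=C(O)C[C@@H]1C[C@H](C(F)(F)F)CN1c1ccc(Oc2ccccc2C(F)(F)F)cc1` gives 310 nM in a functional assay on cells for agonist activity at Free fatty acid receptor 1 (Homo sapiens), read by FLIPR and calcium flux, with a stated time of 100 s (on this read-out lower numbers stand for an effect already at smaller amounts and higher numbers for an effect only at larger amounts of compound), the highest of the three numbers measured so far; compound 3 `O=C(O)C[C@@H]1C[C@H](C(F)(F)F)CN1c1ccc(Oc2ccccc2OC(F)(F)F)cc1` gives 170 nM and compound 1 `Cc1ccccc1Cc1ccc(N2C[C@@H](C(F)(F)F)C[C@H]2CC(=O)O)cc1` gives 67 nM. Compound 4 `Cc1cccc(Oc2ccc(N3C[C@@H](C(F)(F)F)C[C@H]3CC(=O)O)cc2)c1C` differs from compound 2 by 2,3-dimethylphenyl in place of 2-(trifluoromethyl)phenyl on an oxygen on an aromatic ring. Going by the values given here, the only measured step at this position, a 1.8-fold lower number from compound 2 to compound 3 (0.26 log units; within the scatter), stayed within the scatter, and no measured pair exchanges one substituted phenyl ring for another on the ether oxygen, so the change is only loosely anchored by the data. Compound 4 is nevertheless expected to give a somewhat lower number than compound 2. The expected step is a 2.1-fold lower number from compound 2 to compound 4 (0.32 log units; beyond the scatter). Compound 4 is estimated at 150 nM, with a range from 50 nM to 450 nM.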

Compound 4, half-maximal effective concentration: 110 nM
Compound 4: middle estimate off by 1.4-fold (0.13 log units), on the high side, within the range that was stated.
By their numbers in this assay, from the lowest: compounds 1, 4, 3 and 2 (each within the scatter of the next, the first and the last beyond it).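

Placing 2,3-dimethylphenyl on the ether oxygen in place of 2-(trifluoromethyl)phenyl gave a 2.8-fold lower number from compound 2 to compound 4 (0.45 log units; beyond the scatter), the first step at this position to lie beyond the scatter. Exchanging 2-methylbenzyl for 2,3-dimethylphenoxy on an aromatic carbon gave a 1.6-fold higher number from compound 1 to compound 4 (0.22 log units; within the scatter), so the two linkages, each with its own ring, stay indistinguishable here. Nothing at hand gives a reason for either step. The compounds shown leave open whether the loss of trifluoromethyl or the presence of two methyl groups carries the step. They also leave open how a methoxy group, a chlorine or an amine on that phenyl ring would read.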